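Sulfonyl aryl swap from compound 2 to compound 3

A few compounds are considered here, and "the series" means these few. Any claim that something is new, unique, unknown or untested is made for them only; others in the source may bear on it.

Measured in a functional assay on HL-60 cells (Homo sapiens) for inhibition, read by CCK-8 assay, with a stated time of 48 h, tested at 20 uM; a lower number here means less inhibition of growth, a higher number more inhibition of growth at the concentration tested:
compound 1 `COc1ccc(Cc2nnc(NC(=O)/C(C#N)=C/c3ccccc3OS(=O)(=O)c3ccccc3[N+](=O)[O-])s2)cc1`: 25%
compound 2 `COc1ccc(S(=O)(=O)Oc2ccccc2/C=C(\C#N)C(=O)Nc2nnc(Cc3ccc(F)cc3)s2)cc1`: 100%

Compound 2 stands highest of the two at 100%, beyond the scatter above compound 1. Compound 3 `N#C/C(=C\c1ccccc1OS(=O)(=O)c1ccccc1[N+](=O)[O-])C(=O)Nc1nnc(Cc2ccc(F)cc2)s1` changes compound 2 in one place: 2-nitrophenyl in place of 4-methoxyphenyl on a sulfonyl sulfur. Among the measured compounds shown here, no measured pair isolates this change. Compound 1 carries the same 2-nitrophenyl on its sulfonyl sulfur and gives 25%, but it differs from compound 2 elsewhere too, so its gap cannot be assigned to this group alone. On that evidence, a fall in this assay beyond the scatter is expected, smaller than the gap between the measured pair. The estimated step is a number 45 percentage points lower from compound 2 to compound 3 (beyond the scatter). For compound 3 the estimate is 55%, with an expected range of 25% to 95%.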

Compound 3, percent growth inhibition at one concentration: 35%
Beside the measured number, compound 3's estimate is 20 percentage points above it, and the stated range covers the measured number.
By their numbers in this assay, from the lowest: compounds 1 and 3 (each within the scatter of the next); then compound 2.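

In this assay, among the compounds shown here, a number 65 percentage points lower from compound 2 to compound 3 (beyond the scatter), which gives the first one-place reading at this sulfonyl sulfur: 2-nitrophenyl in place of 4-methoxyphenyl is a large loss of growth inhibition with the rest of the structure held constant. With 2-nitrophenyl on the sulfur, fluoro in place of methoxy on an aromatic carbon gives a number 10 percentage points higher from compound 1 to compound 3 (within the scatter), so that change does not separate these two compounds. Nothing measured here accounts for the step at the sulfonyl sulfur.

On these data alone, whether the loss follows the arrival of the nitro group or the departure of the methoxy group remains open, and a plain phenyl or a 4-aminophenyl on the sulfonyl sulfur would help separate the two. Also open, as far as these compounds go, is whether fluoro and methoxy stay equally close with 4-methoxyphenyl on the sulfur.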